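Hydroxyl Position and Cytotoxicity Across Two Related Cores

The source may hold more compounds than are shown below. What is called first, only, known or untested is meant among the compounds shown, and "the series" means these compounds.

Measured so far in a functional assay on HCT-15 cells (Homo sapiens) for cytotoxicity, read by CCK-8 assay and cell counting, with a stated time of 2 days; on this read-out lower numbers stand for stronger inhibition and higher numbers for weaker inhibition:
- compound 1 `Oc1ccc(-c2cc(-c3cccc(Cl)c3)nc(-c3cccs3)c2)cc1` gives 5050 nM
- compound 2 `Oc1cccc(-c2cc(-c3ccccc3)nc(-c3ccc(Cl)cc3)c2)c1` gives 8110 nM
- compound 3 `Oc1cccc(-c2cc(-c3cccc(Cl)c3)nc(-c3cccs3)c2)c1` gives 2610 nM

Compound 1 arises from compound 3 by the change (4-hydroxyphenyl in place of 3-hydroxyphenyl on an aromatic carbon), and this gave a 1.9-fold higher number from compound 3 to compound 1 (0.29 log units; within the scatter). Compound 4 `Oc1ccc(-c2cc(-c3ccccc3)nc(-c3ccc(Cl)cc3)c2)cc1` is made from compound 2 by 4-hydroxyphenyl in place of 3-hydroxyphenyl on an aromatic carbon. The difference between the two cores is not broken down here. The surroundings of the place differ: in compound 3 it is meta to a 3-chlorophenyl group and meta to a thiophen-2-yl group, in compound 2 meta to a 4-chlorophenyl group and meta to a phenyl group, so this is the same kind of change, not the same. A step of about a 1.5-fold higher number from compound 2 to compound 4 (0.17 log units; within the scatter) is expected beside a 1.9-fold higher number from compound 3 to compound 1 (0.29 log units; within the scatter), resting on compound 3 at 2610 nM and compound 1 at 5050 nM. Compound 4 is therefore estimated at 12000 nM, between 5500 nM and 28000 nM.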

Compound 4, half-maximal inhibitory concentration: 6920 nM
Compound 4: middle estimate off by 1.7-fold (0.24 log units), on the high side; the measured number falls inside the stated range.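

On the second core, 4-hydroxyphenyl in place of 3-hydroxyphenyl gives a 1.2-fold lower number from compound 2 to compound 4 (0.07 log units; within the scatter) in this assay. Set beside the same change on the other core, the two steps cannot be told apart: the same change on two cores in this assay, a 1.9-fold higher number (0.29 log units; within the scatter) from compound 3 to compound 1 and a 1.2-fold lower number (0.07 log units; within the scatter) from compound 2 to compound 4, 2.3-fold (0.36 log units) apart, within the scatter of two such steps The change therefore carries across these two cores without a detectable difference, but since each step lies within the scatter, this does not show that moving the hydroxyl alters cytotoxicity on either core, or that a third core would behave the same way.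

Every compound shown carries a hydroxyl on the phenyl group at this place. Going by these compounds, it remains open what an amine or a methoxy group there would do to the number.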